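A few compounds are considered here, and "the series" means these few. Any claim that something is new, unique, unknown or untested is made for them only; others in the source may bear on it.

Measured in a functional assay on K562 cells (Homo sapiens) for antiproliferative activity, read by MTT assay, with a stated time of 48 h; a higher number here means a weaker inhibitor, a lower number a stronger inhibitor:
- compound 1 `CN(C)CCn1c(N)c(-c2nc3ccccc3n2C)c2nc(C#N)c(C#N)nc21`: > 50000 nM, a limit of the assay and not a number
- compound 2 `CN(C)CCCCn1c(N)c(-c2nc3ccccc3n2C)c2nc(C#N)c(C#N)nc21`: 1450 nM
- compound 3 `CCN(CC)CCCCn1c(N)c(-c2nc3ccccc3n2C)c2nc(C#N)c(C#N)nc21`: 1010 nM

Compound 3 carries one of the two actual numbers in this assay, and a 1.4-fold lower number from compound 2 to compound 3 (0.16 log units; within the scatter) shows that it sits level with compound 2. Compound 4 `CCN(CC)CCCCn1c(N)c(-c2nc3cc(Cl)ccc3[nH]2)c2nc(C#N)c(C#N)nc21` keeps the 4-(diethylamino)butyl group of compound 3 but has 5-chloro-1H-benzimidazol-2-yl in place of 1-methyl-1H-benzimidazol-2-yl on an aromatic carbon.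

Within the data shown here, none of the measured steps touches this group. The two large ones, an at least 34-fold lower number from compound 1 to compound 2 (1.53 log units; beyond the scatter) and an at least 49-fold lower number from compound 1 to compound 3 (1.69 log units; beyond the scatter), change the chain on the aromatic nitrogen, which stays the same here. The expectation therefore rests on compound 3 at 1010 nM, with no direction established and a wide margin either way. The expected change is a 1.3-fold lower number from compound 3 to compound 4 (0.10 log units; within the scatter), so no step beyond the scatter is anticipated. For compound 4 the estimated value is 800 nM, with an expected range from 200 nM to 3500 nM.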

Compound 4, half-maximal inhibitory concentration: 1270 nM
The estimate for compound 4 lay 1.6-fold (0.20 log units) below the measured number, within the range that was stated.
By their numbers in this assay, from the lowest: compounds 3, 4 and 2 (each within the scatter of the next). At a limit, above all of these: compound 1.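

In this assay, exchanging 1-methyl-1H-benzimidazol-2-yl for 5-chloro-1H-benzimidazol-2-yl gives a 1.3-fold higher number from compound 3 to compound 4 (0.10 log units; within the scatter) while the 4-(diethylamino)butyl group stays in place. This is the first step shown at this aromatic carbon, and it shows that the place accepts a group carrying a chlorine and 1 hydrogen-bond donor, where the group that leaves has neither, with no difference beyond the scatter. No measurement shown speaks to the reason for this result.

Going by these compounds, since the methyl leaves and the chlorine enters in one step, their separate contributions remain open, and a plain 1H-benzimidazol-2-yl or a 5-chloro-1-methyl-1H-benzimidazol-2-yl group would tell them apart. Also open, on these data alone, is how a 5-fluoro or 5-methoxy group would read at this place.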